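Furan to thiophene on the carbonyl carbon of compound 3

The source may report more compounds than this note shows. Statements on the series, on what has been measured and on what is new or still open speak of the compounds shown alone.

Of the compounds shown here, three built on one shared core have been measured in a functional assay on MDA-MB-231 cells (Homo sapiens) for antiproliferative activity, read by XTT assay, with a stated time of 72 h; on this read-out higher numbers stand for weaker inhibition and lower numbers for stronger inhibition. Compound 1 `COc1ccc(-c2cc3ccccc3nc2/C=C/C(=O)c2c(OC)cccc2OC)cc1` gives 5630 nM. Compound 2 `COc1ccc(-c2cc3ccccc3nc2/C=C/C(=O)c2ccc([N+](=O)[O-])cc2)cc1` gives 840 nM. Compound 3 `COc1ccc(-c2cc3ccccc3nc2/C=C/C(=O)c2ccco2)cc1` gives 630 nM. On these numbers compound 3 carries the lowest value, but its gap to compound 2 lies within the scatter, so the two cannot be ordered; only compound 1 stands clearly apart, through the steps of a 6.7-fold lower number from compound 1 to compound 2 (0.83 log units; beyond the scatter) and an 8.9-fold lower number from compound 1 to compound 3 (0.95 log units; beyond the scatter).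

Compound 4 `COc1ccc(-c2cc3ccccc3nc2/C=C/C(=O)c2cccs2)cc1` is not yet measured. It differs from compound 3 in one place: thiophen-2-yl in place of furan-2-yl on a carbonyl carbon. For the measured compounds named here, no measured step exchanges one five-membered aromatic ring for another, so the bearing on this change is indirect. The closest comparison is the exchange of groups on the same carbonyl carbon, a 1.3-fold lower number from compound 2 to compound 3 (0.12 log units; within the scatter), which stayed within the scatter even though the two groups differed far more than furan-2-yl and thiophen-2-yl do. Compound 4 is therefore expected to show no step beyond the scatter from compound 3, the expected step being no change at the digits printed from compound 3 to compound 4 (within the scatter). Compound 4 is estimated at 630 nM, with a range from 300 nM to 1300 nM.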

Compound 4, half-maximal inhibitory concentration: 410 nM
For compound 4 the middle estimate is 1.5-fold (0.19 log units) above the measured one, within the range that was stated.
By their numbers in this assay, from the lowest: compounds 4, 3 and 2 (each within the scatter of the next, the first and the last beyond it); then compound 1.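

In this assay the exchange of one five-membered aromatic ring for the other is now measured directly, with a 1.5-fold lower number from compound 3 to compound 4 (0.19 log units; within the scatter) and so furan-2-yl and thiophen-2-yl cannot be told apart on this carbonyl carbon, although oxygen gives way to sulfur in the ring. Against 4-nitrophenyl the picture sharpens slightly: the step of a 2.0-fold lower number from compound 2 to compound 4 (0.31 log units; beyond the scatter) only just clears the scatter, a separation that furan-2-yl did not reach, so thiophen-2-yl is the only one of the two five-membered rings set apart from that group. The step of a 14-fold lower number from compound 1 to compound 4 (1.14 log units; beyond the scatter) is the largest seen at this position and the only one graded large, which leaves 2,6-dimethoxyphenyl as the clear outlier among the four groups on this carbon.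

On these data alone, whether this position accepts a five-membered ring with nitrogen in it, such as pyrrol-2-yl or thiazol-2-yl, or an unsubstituted phenyl or a phenyl carrying an amine, stays open, as does whether the same ranking holds in other cell lines. Nothing given here accounts for why these groups fall as they do.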